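This account rests on a few compounds, and the source may have more. Where it says the series, first, only, none or still open, it means among the compounds named here.

Values in a physicochemical assay for solubility, measured as kinetic solubility; a lower number here means a less soluble compound, a higher number a more soluble compound:
- compound 1 `CNc1nccc(N2CC[C@H](NC(=O)Nc3ccc(Cl)c(C(F)(F)F)c3)C2)n1`: 22200 nM
- compound 2 `O=C(Nc1ccc(Cl)c(C(F)(F)F)c1)N[C@H]1CCN(c2ccncn2)C1`: 2400 nM

Compound 1 stands highest of these two numbers. Not yet measured is compound 3 `CNc1nccc(N2CC[C@H](NC(=O)Nc3ccc(CN4CCN(C)CC4)c(C(F)(F)F)c3)C2)n1`, which differs from compound 1 as follows: (4-methylpiperazin-1-yl)methyl in place of chloro on an aromatic carbon, that is, (4-methylpiperazin-1-yl)methyl in place of chloro, on an aromatic carbon ortho to a trifluoromethyl group.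

For the measured compounds named here, only one measured step bears on this, and only indirectly: a 9.3-fold lower number from compound 1 to compound 2 (0.97 log units; beyond the scatter), hydrogen in place of methylamino, at another place in the molecule. Going by the values given here, no measured step covers the place changed in compound 3. A rise in this assay beyond the scatter is nevertheless expected, no larger than that measured step. The expected step is a 3.6-fold higher number from compound 1 to compound 3 (0.56 log units; beyond the scatter) by this estimate. Compound 3 is estimated at 80000 nM with an expected range of 25000 nM to 200000 nM overall.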

Compound 3, solubility: 67500 nM
The estimate for compound 3 lay 1.2-fold (0.07 log units) above the measured number, within the range that was stated.
By their numbers in this assay, from the lowest: compound 2; then compound 1; then compound 3.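

In this assay, the aromatic carbon ortho to a trifluoromethyl group now has a measured change of its own: a 3.0-fold higher number from compound 1 to compound 3 (0.48 log units; beyond the scatter), with (4-methylpiperazin-1-yl)methyl in place of chloro. The earlier step, a 9.3-fold lower number from compound 1 to compound 2 (0.97 log units; beyond the scatter), lay at another place in the molecule, so the read-out is now seen to move at two separate places on the shared core, and here in the upward direction. Nothing on hand explains the size or direction of the new step.

For the compounds shown here, the single swap removes chloro and adds the methylene, the piperazine ring and its methyl together, so the share of each in the step stays open. Open too, from the compounds shown here alone, is whether morpholin-4-ylmethyl, dimethylaminomethyl or plain hydrogen at this position would give a similar number, and whether the same swap on compound 2 would give a step of similar size.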